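Amine Substituent Variation in a Diaryl Ether Series

A few compounds are considered here, and "the series" means these few. Any claim that something is new, unique, unknown or untested is made for them only; others in the source may bear on it.

Measured compounds:
compound 1, `COc1cc(Oc2cccc(Nc3ccccc3)c2)cc(OC)c1CNCc1ccc(C)cc1`, 5400 nM
compound 2, `COc1cc(Oc2cccc(Nc3ccccc3)c2)cc(OC)c1CN[C@H](C)c1ccccc1`, 7550 nM

Compound 2 stands at the higher of the two numbers obtained in a functional assay on HCT-15 cells (Homo sapiens) for inhibition, read by MTT assay, with a stated time of 72 h; a lower number here means a stronger inhibitor, a higher number a weaker inhibitor; its nearest neighbour, compound 1, lies a 1.4-fold higher number from compound 1 to compound 2 (0.15 log units; within the scatter) step away, which is within the scatter, so the two are not distinguishable. Compound 3, `COc1ccc(CCCNCc2c(OC)cc(Oc3cccc(Nc4ccccc4)c3)cc2OC)cc1`, has not been measured. Relative to compound 2 the change is 3-(4-methoxyphenyl)propyl in place of 1-phenylethyl on an amine nitrogen. Among the measured compounds shown here, only one measured step exists, and it concerns a different exchange on the same amine nitrogen; it was a 1.4-fold higher number from compound 1 to compound 2 (0.15 log units; within the scatter), within the scatter. For the measured compounds named here, no measured step bears directly on the change to a longer chain bearing a methoxy group. With only this small, non-significant step available, compound 3 is estimated to differ from compound 2 by no more than the scatter, an expected step of a 1.2-fold lower number from compound 2 to compound 3 (0.07 log units; within the scatter). Compound 3 is therefore expected to give about 6500 nM, in the range 2500 nM to 17000 nM.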

Compound 3, half-maximal inhibitory concentration: 730 nM
Compound 3: middle estimate off by 8.9-fold (0.95 log units), on the high side; the whole stated range lies above it.
By their numbers in this assay, from the lowest: compound 3; then compounds 1 and 2 (each within the scatter of the next).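

Where the exchange of 4-methylbenzyl for 1-phenylethyl left the number within the scatter, this amine nitrogen proves not to be indifferent to its substituent: in this assay the 3-(4-methoxyphenyl)propyl group gives a 10-fold lower number from compound 2 to compound 3 (1.01 log units; beyond the scatter) and also a 7.4-fold lower number from compound 1 to compound 3 (0.87 log units; beyond the scatter) as a second step beyond the scatter. Compound 3 therefore stands apart as the strongest inhibitor of the three, with its steps to both others beyond the scatter, so a substituent on this nitrogen can shift the number far more than the first pair suggested. Nothing available accounts for this difference.

The change brings a longer chain and a methoxy group together, and the compounds shown do not separate the two, since neither 3-phenylpropyl nor 4-methoxybenzyl appears among them. Also open, as far as these compounds go, is how a chloro group in place of the methoxy group, or a still longer chain, would fare on this nitrogen.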